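This account rests on a few compounds, and the source may have more. Where it says the series, first, only, none or still open, it means among the compounds named here.

Measured in a functional assay on U-251 cells (Homo sapiens) for antiproliferative activity, read by MTT assay, with a stated time of 48 h; a higher number here means a weaker inhibitor, a lower number a stronger inhibitor:
Compound 1 `COc1cc(-c2cccc3nc(-c4ccccc4)oc23)cc(OC)c1OC`: 3500 nM
Compound 2 `COc1cc(-c2cccc3nc(-c4ccc(F)cc4)oc23)cc(OC)c1OC`: > 25000 nM (a limit of the assay)
Compound 3 `COc1cc(-c2cccc3nc(-c4cccc(Br)c4)oc23)cc(OC)c1OC`: 6800 nM

Compound 3 gives 6800 nM in this assay and sits within the scatter of compound 1 . Compound 4 `COc1cc(-c2cccc3nc(-c4cccc(Cl)c4)oc23)cc(OC)c1OC` carries chloro in place of bromo on an aromatic carbon and is otherwise the same as compound 3 . Going by the values given here, two measured steps bear on this change. Bromo in place of hydrogen gave a 1.9-fold higher number from compound 1 to compound 3 (0.29 log units; within the scatter) and so left compound 3 level with compound 1 . Fluoro in place of hydrogen gave an at least 7.1-fold higher number from compound 1 to compound 2 (0.85 log units; beyond the scatter) and shows that a halogen can matter in this series, so the range is kept wide on the weak side. No change beyond the scatter is therefore expected. The expected step is a 1.0-fold lower number from compound 3 to compound 4 (0.02 log units; within the scatter) in this assay. For compound 4 the estimated value is 6500 nM with an expected range from 3000 nM to 16000 nM.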

Compound 4, half-maximal inhibitory concentration: 18500 nM
For compound 4 the middle estimate is 2.8-fold (0.45 log units) below the measured one, and the stated range ends below it.
By their numbers in this assay, from the lowest: compounds 1 and 3 (each within the scatter of the next); then compound 4. At a limit, above all of these: compound 2.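

Chloro in place of bromo is not a neutral exchange at this position: it gives a modest step, a 2.7-fold higher number from compound 3 to compound 4 (0.43 log units; beyond the scatter). Chloro in place of hydrogen gives a 5.3-fold higher number from compound 1 to compound 4 (0.72 log units; beyond the scatter), while bromo stayed within the scatter of hydrogen, so these two halogens do not behave alike here. The value of compound 2 is a limit of the assay: the limit of > 25000 nM in this assay, at which 1 of the 4 values shown sits. 3-Chlorophenyl in place of 4-fluorophenyl gives an at least 1.3-fold lower number from compound 2 to compound 4 (0.13 log units; that floor lies within the scatter), so this step shows no more than that floor.

Going by these compounds, whether an amine or a carboxylic acid at this position would stay level with compound 1 or move as chloro did remains open. So does the effect of fluoro at this same position.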